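Methyl on the Ring Bearing the Urea

The source may report more compounds than this note shows. Statements on the series, on what has been measured and on what is new or still open speak of the compounds shown alone.

Compound 1 `CC(C)(C)c1cc(NC(=O)Nc2ccc(Nc3ncnc4c3OCCN4)cc2)no1`: 58 nM
Compound 2 `Cc1cc(NC(=O)Nc2cc(C(C)(C)C)on2)ccc1Nc1ncnc2c1OCCN2`: 85 nM
Compound 3 `CC(C)(C)c1cc(NC(=O)Nc2ccc(Nc3ncnc4c3OCCN4)nc2)no1`: 54 nM

All three were measured in an assay on isolated protein for inhibition of proto-oncogene tyrosine-protein kinase receptor Ret variant V804L (Homo sapiens), read by 33P incorporation, with stated times of 15 min and 40 min; on this read-out higher numbers stand for weaker inhibition and lower numbers for stronger inhibition. Compound 2 differs from compound 1 in one place: methyl in place of hydrogen on an aromatic carbon. That change gave a 1.5-fold higher number from compound 1 to compound 2 (0.17 log units; within the scatter). Compound 3 has a different core from compound 1; the difference between the two cores is not broken down here, and the two numbers lie within the scatter of each other.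

Compound 4 `Cc1nc(Nc2ncnc3c2OCCN3)ccc1NC(=O)Nc1cc(C(C)(C)C)on1` is not yet measured. It differs from compound 3 in one place: methyl in place of hydrogen on an aromatic carbon. This is the same kind of change as from compound 1 to compound 2, but the place differs: here the six-membered aromatic ring holds 1 nitrogen and the methyl sits next to the ring nitrogen, whereas before the ring was of carbon only. Because the earlier step was a 1.5-fold higher number from compound 1 to compound 2 (0.17 log units; within the scatter), a comparable step is expected for compound 4, namely a 1.5-fold higher number from compound 3 to compound 4 (0.17 log units; within the scatter). The estimate for compound 4 in this assay is 80 nM, expected to lie between 35 nM and 180 nM.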

Compound 4, half-maximal inhibitory concentration: 877 nM
Beside the measured number, compound 4's estimate is 11-fold (1.04 log units) below it; measured number outside the range, above it.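

Placing the methyl on the core of compound 3 gave a 16-fold higher number from compound 3 to compound 4 (1.21 log units; beyond the scatter), so this change did not carry over with the same size from the core of compound 1, and the two steps differ: the same change on two cores in this assay, a 1.5-fold higher number (0.17 log units; within the scatter) from compound 1 to compound 2 and a 16-fold higher number (1.21 log units; beyond the scatter) from compound 3 to compound 4, 11-fold (1.04 log units) apart, beyond the scatter of two such steps On these two cores, then, a step read on one core was a poor guide to the same change on the other. This does not show why the steps differ, and a single pair on each core gives no rule for other cores or other changes.

The compounds shown leave open whether an ethyl or a chlorine in the same place would bring a step as large as that of the methyl. Also open, as far as these compounds go, is whether a fluorine there would be tolerated on both cores.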